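This account rests on a few compounds, and the source may have more. Where it says the series, first, only, none or still open, it means among the compounds named here.

Measured compounds in a functional assay on SK-HEP1 cells (Homo sapiens) for antiproliferative activity, read by sulforhodamine B assay; on this read-out lower numbers stand for stronger inhibition of growth and higher numbers for weaker inhibition of growth:

- compound 1, `O=C(Nc1cccc([N+](=O)[O-])c1)Nc1nc2ccc(Cl)cc2s1`, gives 2.21 ug/mL
- compound 2, `O=C(Nc1cccc([N+](=O)[O-])c1)Nc1nc2ccc(F)cc2s1`, gives 1.96 ug/mL
- compound 3, `COc1cccc2sc(NC(=O)c3ccc(C(F)(F)F)cc3)nc12`, gives only a limit, > 10 ug/mL; this is the limit of > 10 ug/mL in this assay, at which 1 of the 3 values shown sits.

Of the two numbers that are not limits, compound 2 has the lowest, and its nearest neighbour is compound 1, the two lying within the scatter of each other: a 1.1-fold lower number from compound 1 to compound 2 (0.05 log units; within the scatter), a change of fluoro in place of chloro on an aromatic carbon.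

Compound 4, `Cc1ccc2nc(NC(=O)Nc3cccc([N+](=O)[O-])c3)sc2c1`, has not yet been measured in this assay. It differs from compound 2 by methyl in place of fluoro on an aromatic carbon. Among the measured compounds shown here, the only measured step that bears on this position is the halogen swap from compound 1 to compound 2, which stayed within the scatter. For the measured compounds named here, there is no measured step that replaces a halogen with a methyl at this position, so the expectation rests on that single neighbouring step alone. The step from compound 2 to compound 4 is therefore estimated as a 1.1-fold higher number from compound 2 to compound 4 (0.05 log units; within the scatter), not beyond the scatter in either direction. Compound 4 is expected to give about 2.2 ug/mL in this assay, in the range 1 ug/mL to 5 ug/mL.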

Compound 4, concentration for 50% growth inhibition: > 10 ug/mL
Compound 4 was reported as a limit; the forecaster's own chance of this, stated with the estimate: 10%; middle value at least 4.5-fold (0.65 log units) from the limit.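

In this assay, this place on the core turns out to be sensitive to the group it carries, which the swap between the two halogens could not show: an at least 5.1-fold higher number from compound 2 to compound 4 (0.70 log units; beyond the scatter), and an at least 4.5-fold higher number from compound 1 to compound 4 (0.65 log units; beyond the scatter). Fluoro and chloro give values within the scatter of each other, whereas methyl, which replaces a single heavy atom with a single heavy atom, moves the number beyond the scatter. Both steps are only lower bounds, since compound 4 is reported as a limit and not as a number: the limit of > 10 ug/mL in this assay, at which 2 of the 4 values shown sit.

On these data alone, how far past that limit compound 4 really lies remains open, and with it the true size of both steps. Also open, as far as these compounds go, is whether an amine or a hydroxyl group at this place would behave like the halogens or like methyl.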